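A Second Chlorine on Compound 3

The source may hold more compounds than are shown below. What is called first, only, known or untested is meant among the compounds shown, and "the series" means these compounds.

Of the compounds shown here, three sharing one core have been measured in a functional assay on THP-1 cells (Homo sapiens) for cytotoxicity, read by MTT assay, with a stated time of 24 h; on this read-out lower numbers stand for stronger inhibition and higher numbers for weaker inhibition. Compound 1 (`CN1C/C(=C\c2ccc(C(F)(F)F)cc2)C(=O)/C(=C/c2ccccc2F)C1`) gives 5930 nM, compound 2 (`COc1cc(/C=C2\CN(C)C/C(=C\c3ccc(F)cc3)C2=O)cc(OC)c1`) gives 5040 nM, and compound 3 (`COc1cc(/C=C2\CN(C)C/C(=C\c3ccc(Cl)cc3)C2=O)cc(OC)c1`) gives 5860 nM. Compound 3 lies within the scatter of both other compounds, so the three values form a single narrow group and do not separate into a ranking.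

Compound 4 (`COc1cc(/C=C2\CN(C)C/C(=C\c3ccc(Cl)cc3Cl)C2=O)cc(OC)c1`) turns the 4-chlorophenyl of compound 3 into a 2,4-dichlorophenyl: chloro in place of hydrogen on an aromatic carbon. The new chloro replaces hydrogen on an aromatic carbon, ortho to a large group and meta to the existing chloro group.

Among the measured compounds shown here, only one measured step bears on this change directly. Chloro in place of fluoro gave a 1.2-fold higher number from compound 2 to compound 3 (0.07 log units; within the scatter). For the measured compounds named here, that step exchanges one halogen for another, however, and no measured pair shows a chloro replacing hydrogen, so it offers only limited guidance. Compound 1 differs from compound 3 in more than one place, yet their two values lie within the scatter of each other. No step beyond the scatter is therefore expected, and no direction can be favoured. The expected step is a 1.2-fold lower number from compound 3 to compound 4 (0.07 log units; within the scatter). The estimate for compound 4 is 5000 nM, with an expected range of 2500 nM to 9500 nM.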

Compound 4, half-maximal inhibitory concentration: 6070 nM
Beside the measured number, compound 4's estimate is 1.2-fold (0.08 log units) below it, and the stated range covers the measured number.
By their numbers in this assay, from the lowest: compounds 2, 3, 1 and 4 (each within the scatter of the next).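

In this assay, among the compounds shown here, this is the first measured case of chloro replacing hydrogen rather than another halogen, and it gives a 1.0-fold higher number from compound 3 to compound 4 (0.02 log units; within the scatter). A new chloro on this aromatic carbon, ortho to a large group and meta to a chloro group, therefore leaves the reading within the scatter, whereas the earlier compounds had shown only an exchange of one halogen for another. The wider replacement of 4-fluorophenyl by 2,4-dichlorophenyl gives a 1.2-fold higher number from compound 2 to compound 4 (0.08 log units; within the scatter), so the combined change on this ring also stays within the scatter, and nothing beyond these numbers is available to account for the result.

Every change on this ring shown so far is a halogen, so it remains open whether an amine or a carboxylic acid on the same aromatic carbon would give a step beyond the scatter. On these data alone, with all four compounds forming one narrow group, it is also open whether any change to the shared core can separate them in this assay.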